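Triazole ester series: cyclohexyl in place of isopropyl

The source may report more compounds than this note shows. Statements on the series, on what has been measured and on what is new or still open speak of the compounds shown alone.

Three compounds of the shared core have been run in a functional assay on NPC-TW01 cells (Homo sapiens) for inhibition, read by MTT assay, with a stated time of 72 h; a higher number here means a weaker inhibitor of growth, a lower number a stronger inhibitor of growth. Compound 1 `COC(=O)c1nc(C)n(-c2cccc(C(F)(F)F)c2)n1` gives only a limit, > 100000 nM. Compound 2 `COC(=O)c1nc(C)n(-c2ccc(OC)cc2)n1` gives 9920 nM. Compound 3 `COC(=O)c1nc(C(C)C)n(-c2ccc(F)cc2)n1` also gives only a limit, > 100000 nM. Among the measured compounds shown here, compound 3 therefore stands at the limit of > 100000 nM in this assay, at which 2 of the 3 values shown sit, in this assay, and no step between two measured compounds is available to set a scale. Compound 4 `COC(=O)c1nc(C2CCCCC2)n(-c2ccc(F)cc2)n1` differs from compound 3 by cyclohexyl in place of isopropyl on an aromatic carbon. For the measured compounds named here, with no measured step to lean on, the expected step of an at least 1.1-fold lower number from compound 3 to compound 4 (0.04 log units; that floor lies within the scatter) is none beyond the scatter. Compound 4 is thus expected to come out near 90000 nM in this assay, with a range from 20000 nM to 300000 nM, and most likely as a limit again.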

Compound 4, concentration for 50% growth inhibition: 30500 nM
For compound 4 the middle estimate is 3.0-fold (0.47 log units) above the measured one, and the stated range covers the measured number.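

In this assay, the group on the aromatic carbon between two ring nitrogen atoms matters: cyclohexyl in place of isopropyl gives an at least 3.2-fold lower number from compound 3 to compound 4 (0.51 log units; beyond the scatter). Compound 3 is a limit and not a number, so this step has only a floor: the limit of > 100000 nM in this assay, at which 2 of the 4 values shown sit.

With the rest of the structure unchanged, one six-membered non-aromatic ring of carbon only at this position gives a measured value. As far as these compounds go, whether the ring itself or the carbon count matters stays open; a hexyl chain or a phenyl ring here would separate the two. Also open, from the compounds shown here alone, is whether cyclohexyl has the same effect on the core of compound 2.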